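This account rests on a few compounds, and the source may have more. Where it says the series, first, only, none or still open, it means among the compounds named here.

In a functional assay on A549 cells (Homo sapiens) for cytotoxicity, read by MTT assay, with a stated time of 48 h (on this read-out lower numbers stand for stronger inhibition and higher numbers for weaker inhibition), three esters on a shared core have been measured. Compound 1 `C=C1C(=O)O[C@H]2CC3=C[C@H](C/C(C)=C/[C@@H](OC(=O)CCCCBr)[C@H]12)OC3=O` gives > 10000 nM, which is a limit of the assay and not a number. Compound 2 `C=C1C(=O)O[C@H]2CC3=C[C@H](C/C(C)=C/[C@@H](OC(=O)CCl)[C@H]12)OC3=O` gives > 10000 nM, also a limit. Within the data shown here, compound 3 `C=C1C(=O)O[C@H]2CC3=C[C@H](C/C(C)=C/[C@@H](OC(=O)/C=C/c4cccs4)[C@H]12)OC3=O` gives 4300 nM, the only true number in the set, and it is the sole compound seen to inhibit within the measured range.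

Compound 4 `C=C1C(=O)O[C@H]2CC3=C[C@H](C/C(C)=C/[C@@H](OC(=O)c4ccncc4)[C@H]12)OC3=O` differs from compound 3 in one place, where pyridin-4-yl stands in place of 2-(thiophen-2-yl)ethenyl on a carbonyl carbon: pyridin-4-yl in place of 2-(thiophen-2-yl)ethenyl on a carbonyl carbon. Among the measured compounds shown here, the steps that bear on this are the two by which 2-(thiophen-2-yl)ethenyl arrived, an at least 2.3-fold lower number from compound 1 to compound 3 (0.36 log units; beyond the scatter) and an at least 2.3-fold lower number from compound 2 to compound 3 (0.36 log units; beyond the scatter). Both sizes are bounded only by the limit of > 10000 nM in this assay, at which 2 of the 3 values shown sit, so the true gains may be larger. The remaining step, a step that the two limits leave unreadable from compound 1 to compound 2, adds nothing. For the measured compounds named here, no measured step involves pyridin-4-yl, so the size of this change remains uncertain. Since compound 3 reached 4300 nM with the group that now leaves, some loss is the likelier outcome in this assay. The expected change is a 2.1-fold higher number from compound 3 to compound 4 (0.32 log units; beyond the scatter), towards weaker inhibition. For compound 4 the estimated value is 9000 nM, with an expected range of 3500 nM to 20000 nM.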

Compound 4, half-maximal inhibitory concentration: > 10000 nM
Compound 4 was reported as a limit; the forecaster's own chance of this, stated with the estimate: 55%; at least 1.1-fold (0.04 log units) between middle value and limit.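

In this assay, pyridin-4-yl in place of 2-(thiophen-2-yl)ethenyl on a carbonyl carbon gives an at least 2.3-fold higher number from compound 3 to compound 4 (0.36 log units; beyond the scatter), so this position also responds to a change between two aromatic groups, not only to the change from the halogenated chains. Among these compounds, the earlier limits came only from chloromethyl and 4-bromobutyl, whereas this result shows that an aromatic ring in the entering group is not enough on its own to keep a measured value, and compound 3 remains the only compound with a true number. The steps from compound 1 and from compound 2 to compound 4 cannot be read, because all three compounds sit at a limit: the limit of > 10000 nM in this assay, at which 3 of the 4 values shown sit.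

The change swaps the ring and also removes the double bond outside aromatic rings, so the compounds shown do not tell which of these accounts for the step. A 2-(pyridin-4-yl)ethenyl group or a thiophen-2-yl group on the same carbonyl carbon would separate the two, and a 2-phenylethenyl group would show whether the thiophene ring is needed at all.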